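Compound 4: methyl in place of chloro

The source may report more compounds than this note shows. Statements on the series, on what has been measured and on what is new or still open speak of the compounds shown alone.

Measured in a physicochemical assay for solubility, read by nephelometry, in phosphate buffer, measured as kinetic solubility, at pH 7.4; on this read-out lower numbers stand for lower solubility and higher numbers for higher solubility:
- compound 1 `C=CC(=O)Nc1ccc(-n2nc3c(=O)[nH]nc(N)c3c2-c2oc3ccc(Cl)cc3c2C)cc1`: 20000 nM
- compound 2 `C=CC(=O)Nc1ccc(-n2nc3c(=O)[nH]nc(N)c3c2-c2oc3ccc(C)cc3c2C)cc1`: 20000 nM
- compound 3 `Cc1c(-c2c3c(N)n[nH]c(=O)c3nn2-c2ccc(NC(=O)/C=C/CN(C)C)cc2)oc2ccc(Cl)cc12`: 200000 nM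

Compound 3 stands highest of the three numbers in this assay, at 200000 nM. Its exchange of 3-(dimethylamino)prop-1-en-1-yl in place of vinyl on a carbonyl carbon shows a 10-fold higher number from compound 1 to compound 3 (1.00 log units; beyond the scatter).

Compound 4 `Cc1ccc2oc(-c3c4c(N)n[nH]c(=O)c4nn3-c3ccc(NC(=O)/C=C/CN(C)C)cc3)c(C)c2c1` carries methyl in place of chloro on an aromatic carbon. Going by the values given here, only one measured pair bears on this exchange, and it carries vinyl on the carbonyl carbon, showing no change at the digits printed from compound 1 to compound 2 (within the scatter). That single pair gives no reason to expect a change beyond the scatter. The expected step is no change at the digits printed from compound 3 to compound 4 (within the scatter). The estimate for compound 4 is 200000 nM, with an expected range of 90000 nM to 350000 nM.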

Compound 4, solubility: 50000 nM
Estimate against measurement, compound 4: 4.0-fold (0.60 log units) above, and the stated range ends above it.
By their numbers in this assay, from the lowest: compounds 1 and 2 (each within the scatter of the next); then compound 4; then compound 3.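

In this assay, methyl in place of chloro on this aromatic carbon does not behave the same in every setting: with 3-(dimethylamino)prop-1-en-1-yl on the carbonyl carbon it gives (a 4.0-fold lower number from compound 3 to compound 4 (0.60 log units; beyond the scatter)), while with vinyl there it gives (no change at the digits printed from compound 1 to compound 2 (within the scatter)). The chain exchange still raises the number in the methyl pair (a 2.5-fold higher number from compound 2 to compound 4 (0.40 log units; beyond the scatter)), as it does in the chloro pair (a 10-fold higher number from compound 1 to compound 3 (1.00 log units; beyond the scatter)). No measurement at hand explains this dependence on the chain.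

On these data alone, whether fluoro or methoxy on this aromatic carbon would track chloro or methyl remains open. So does the outcome with a piperidine in place of the dimethylamino group.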